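Adding one methyl to a chain at the assay limit

The source may hold more compounds than are shown below. What is called first, only, known or untested is meant among the compounds shown, and "the series" means these compounds.

Measured in an ADME assay on A549 cells (Homo sapiens) for cytotoxicity, read by MTT assay (a lower number here means that less compound is tolerated, a higher number that more compound is tolerated), where all three entries are limits:
compound 1 `CCN(c1ccccc1C)S(=O)(=O)c1cc(Cl)ccc1Cl` > 25000 nM
compound 2 `C=CCN(c1ccccc1C)S(=O)(=O)c1cc(Cl)ccc1Cl` > 5000 nM
compound 3 `C#CCN(c1ccccc1C)S(=O)(=O)c1cc(Cl)ccc1Cl` > 5000 nM

Compound 1 has no exact number and stands at the limit of > 25000 nM in this assay, at which 1 of the 3 values shown sits, in the data so far. Compound 2 and compound 3 stand at the limit of > 5000 nM in this assay, at which 2 of the 3 values shown sit, and give no exact number either.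

Compound 4 `Cc1ccccc1N(C(C)C)S(=O)(=O)c1cc(Cl)ccc1Cl` differs from compound 1 by methyl in place of hydrogen on a saturated chain carbon bound to a saturated chain carbon and a sulfonamide nitrogen, which reads as ethyl to isopropyl (methyl in place of hydrogen on a saturated chain carbon bound to a saturated chain carbon and a sulfonamide nitrogen).

Within the data shown here, three measured steps bear on this change, since each alters a group on a saturated chain carbon bound to a sulfonamide nitrogen. They are a step that the two limits leave unreadable from compound 1 to compound 2 and a step that the two limits leave unreadable from compound 1 to compound 3 and also a step that the two limits leave unreadable from compound 2 to compound 3 so none offers a size to carry over. No step beyond the usual scatter is therefore expected in this assay in either direction. Compound 1 remains the only anchor, with > 25000 nM as a limit. The expected step is a number no higher from compound 1 to compound 4 (the limit leaves the size open) and it is only a cautious guess. For compound 4 the estimated value is 25000 nM with an expected range from 7000 nM to 70000 nM and most likely only a limit will be reported.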

Compound 4, half-maximal cytotoxic concentration: > 5000 nM
Compound 4: a limit, no number; the forecaster's own chance of this, stated with the estimate: 85%; the middle value is on the limit's open side.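

Among these compounds, compound 4 gives only a limit, as do compound 1, compound 2 and compound 3, so no step from any of them to compound 4 can be read in this assay. These compounds leave open how much the change from ethyl to isopropyl shifts the tolerated concentration, or whether it shifts it at all.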